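This account rests on a few compounds, and the source may have more. Where it says the series, first, only, none or still open, it means among the compounds named here.

Three close relatives share one core, and each has been tested in an assay for inhibition of ribosomal protein S6 kinase beta-1 variant D18H,T412E (Homo sapiens), read by a luciferase reporter and chemiluminescence, with a stated time of 3 h; a lower number here means a stronger inhibitor, a higher number a weaker inhibitor. Compound 1 `Cc1ccc(Cl)cc1N1CCN(c2ncnc(N)c2[N+](=O)[O-])CC1` gives 3 nM in this assay. Compound 2 `Cc1ccc(Cl)cc1N1CCN(c2ncnc3[nH]nc(C)c23)CC1` gives 9 nM in this assay. Compound 3 `CCc1n[nH]c2ncnc(N3CCN(c4cc(Cl)ccc4C)CC3)c12` gives 6 nM in this assay. These numbers sit close together: the measured step of a 1.5-fold lower number from compound 2 to compound 3 (0.18 log units; within the scatter) stays within the usual scatter of repeated measurements, and the gap between compound 3 and compound 1 is also no wider than that scatter, so nothing separates the three with confidence.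

Compound 4 `CCCc1n[nH]c2ncnc(N3CCN(c4cc(Cl)ccc4C)CC3)c12` has not yet been measured. It differs from compound 3 by methyl in place of hydrogen on a saturated chain carbon, two bonds along the chain from an aromatic carbon. Within the data shown here, the one measured step that bears on this, a 1.5-fold lower number from compound 2 to compound 3 (0.18 log units; within the scatter), lengthened the same chain by a single carbon and changed the number by less than the scatter, so a further lengthening of one carbon is expected to change little in this assay, in no particular direction. The step is expected to be a 1.2-fold higher number from compound 3 to compound 4 (0.07 log units; within the scatter). Compound 4 is therefore expected to give about 7 nM in this assay, within a range from 3 nM to 17 nM.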

Compound 4, half-maximal inhibitory concentration: 6 nM
The estimate for compound 4 lay 1.2-fold (0.07 log units) above the measured number, and the stated range covers the measured number.
By their numbers in this assay, from the lowest: compounds 1, 3, 4 and 2 (each within the scatter of the next, the first and the last beyond it).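

Along the chain on the shared core, the compounds now run from methyl through ethyl to propyl, and in this assay the added carbon of propyl gives no change at the digits printed from compound 3 to compound 4 (within the scatter) with no shift that can be told from noise. Measured across both added carbons together, the chain extension gives a 1.5-fold lower number from compound 2 to compound 4 (0.18 log units; within the scatter) and this too stays within the scatter, so none of the three chain lengths stands apart from the others in this assay. What lies behind this flat response to chain length cannot be said, as no supporting evidence on that point is available here.

On these data alone, these three chains are all short and unbranched, so how far the position would accept a longer chain such as butyl remains open. A branched isopropyl group, a cyclopropyl ring or a chain ending in an amine or a carboxylic acid could behave quite differently at this position.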